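Furan-3-yl in place of (pyridin-2-yl)methyl

The source may hold more compounds than are shown below. What is called first, only, known or untested is meant among the compounds shown, and "the series" means these compounds.

In a functional assay on cells (Platelet, Homo sapiens) for inhibition (a lower number here means a stronger inhibitor, a higher number a weaker inhibitor), compound 1 `CCOC(=O)c1ccc(-c2nn(Cc3ccccc3OC)c3ccccc23)cc1` gives > 10000 nM, a limit and not a number. Compound 2 `CCOC(=O)c1ccc(-c2nn(Cc3cccc(OC)c3)c3ccccc23)cc1` gives > 10000 nM, also a limit. Compound 3 `CCOC(=O)c1ccc(-c2nn(Cc3ccccn3)c3ccccc23)cc1` gives > 10000 nM, again a limit, so its standing is known only as the limit of > 10000 nM in this assay, at which 3 of the 3 values shown sit.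

The next structure is compound 4 `CCOC(=O)c1ccc(-c2nn(-c3ccoc3)c3ccccc23)cc1`, reached through (furan-3-yl in place of (pyridin-2-yl)methyl on an aromatic nitrogen).

The nearest measured changes are a step that the two limits leave unreadable from compound 1 to compound 3, a step that the two limits leave unreadable from compound 2 to compound 3 and a step that the two limits leave unreadable from compound 1 to compound 2. None has a readable size, and none replaces the whole (pyridin-2-yl)methyl group, so they offer no size or direction to carry over. The expected change is therefore a number no higher from compound 3 to compound 4 (the limit leaves the size open), with no firm direction. For compound 4 the estimated value is 10000 nM, with an expected range of 3000 nM to 30000 nM.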

Compound 4, half-maximal inhibitory concentration: > 10000 nM
Compound 4: a limit, no number (the forecaster's own chance of this, stated with the estimate: 75%); the middle value sits exactly at the limit.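

The steps from compound 1, compound 2 and compound 3 to compound 4 cannot be read, all four values being limits: the limit of > 10000 nM in this assay, at which 4 of the 4 values shown sit.

The compounds shown leave open which group on the aromatic nitrogen, if any, gives a readable number in this assay.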